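This account rests on a few compounds, and the source may have more. Where it says the series, first, only, none or still open, it means among the compounds named here.

Going by the values given here, in a functional assay on HeLa cells (Homo sapiens) for inhibition, read by CCK-8 assay, with a stated time of 48 h (on this read-out lower numbers stand for stronger inhibition and higher numbers for weaker inhibition), compound 2 `COc1cc(-c2ccnc3cc(-c4ccc5c(ccn5C)c4)nn23)cc(OC)c1OC` gives 19 nM, the lower of the two numbers so far, and compound 1 `COc1cc(-c2ccnc3cc(-c4ccc(F)cc4)nn23)cc(OC)c1OC` gives 5840 nM. Compound 3 `COc1cc(-c2ccnc3cc(-c4ccc5cc[nH]c5c4)nn23)cc(OC)c1OC` is still unmeasured. It has 1H-indol-6-yl in place of 1-methyl-1H-indol-5-yl on an aromatic carbon. Among the compounds with values here, only one measured step bears on this: a 310-fold lower number from compound 1 to compound 2 (2.49 log units; beyond the scatter), a large one at the same place that changed the ring types. This swap keeps the ring types, so a far smaller move towards a higher number in this assay is expected. The estimated step is a 5.3-fold higher number from compound 2 to compound 3 (0.72 log units; beyond the scatter). Compound 3 is expected at 100 nM, with an estimated range from 15 nM to 700 nM.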

Compound 3, half-maximal inhibitory concentration: 125 nM
Compound 3: middle estimate off by 1.3-fold (0.10 log units), on the low side, and the stated range covers the measured number.
By their numbers in this assay, from the lowest: compound 2; then compound 3; then compound 1.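

In this assay, swapping in 1H-indol-6-yl gives a 6.6-fold higher number from compound 2 to compound 3 (0.82 log units; beyond the scatter) and so shows that the two indolyl groups are not interchangeable at this position. The same group still gives a 47-fold lower number from compound 1 to compound 3 (1.67 log units; beyond the scatter) and so shows that the large drop from the 4-fluorophenyl compound does not require 1-methyl-1H-indol-5-yl. No measurement here explains either step.

This swap changes both the ring carbon carrying the bond and the methyl on the indole nitrogen, so 1H-indol-5-yl would be needed to separate them. Going by these compounds, how an ethyl on that nitrogen would read also stays open.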